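From Amide to Ester on a Glutamate Receptor Modulator

This account rests on a few compounds, and the source may have more. Where it says the series, first, only, none or still open, it means among the compounds named here.

Compound 1 `CNC(=O)c1cc(OCCCCOc2ccc(C(=O)CC(C)(C)C)c(O)c2C)ccc1F` is the only one of these compounds with a number in an assay for positive allosteric modulation of metabotropic glutamate receptor 3 (Rattus norvegicus); on this read-out lower numbers stand for an effect already at smaller amounts and higher numbers for an effect only at larger amounts of compound; in this assay compound 1 gives 476 nM. Compound 2 `COc1ccc(OCCCCOc2ccc(C(=O)CC(C)(C)C)c(O)c2C)cc1` carries a methoxy group where compound 1 has its methylcarbamoyl group and lacks the fluorine. In this assay compound 2 is reported as "not active" (no number reported), so no number can be set beside it. The new compound 3 `COC(=O)c1cc(OCCCCOc2ccc(C(=O)CC(C)(C)C)c(O)c2C)ccc1F` keeps everything of compound 1 except one change: methoxy in place of methylamino on a carbonyl carbon. In plain words, the amide becomes an ester. For the measured compounds named here, no measured pair shows this exact exchange, so the expectation rests on compound 1 alone. The step from compound 1 to compound 3 is expected to go toward an effect only at larger amounts, by about a 3.2-fold higher number from compound 1 to compound 3 (0.50 log units; beyond the scatter), beyond the usual scatter. Compound 3 is therefore estimated at 1500 nM, with a range from 400 nM to 8000 nM.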

Compound 3, half-maximal effective concentration: "not active" (no number reported)
For compound 3 the study gives words and no number, so the estimate cannot be set against anything.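

For the compounds shown here, no step from compound 1 to compound 3 can be read: in this assay compound 3 is reported only in words. The compounds shown leave open which groups other than methylamino on that carbonyl carbon would keep a measurable effect. Nothing shown offers an explanation for this result.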